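The source may hold more compounds than are shown below. What is called first, only, known or untested is meant among the compounds shown, and "the series" means these compounds.

Of the compounds shown here, three share a core and have been tested in a functional assay on BXPC-3 cells (Homo sapiens) for inhibition, read by MTT assay, with a stated time of 48 h; on this read-out lower numbers stand for stronger inhibition and higher numbers for weaker inhibition. Compound 1 `COc1cc(C2=NOC(c3c[nH]c4ccccc34)C2)cc(OC)c1OC` gives 13500 nM in this assay. Compound 2 `Cc1[nH]c2ccccc2c1C1CC(c2ccncc2)=NO1` gives 95500 nM in this assay. For compound 3 `Clc1ccc(Cn2cc(C3CC(c4ccncc4)=NO3)c3ccccc32)cc1` the result in this assay is only a limit, > 100000 nM, and it stands at the limit of > 100000 nM in this assay, at which 1 of the 3 values shown sits. Compound 4 `COc1ccc2c(c1)c(C1CC(c3ccncc3)=NO1)cn2Cc1ccc(Cl)cc1` has not yet been measured; it differs from compound 3 by methoxy in place of hydrogen on an aromatic carbon, a methoxy in place of hydrogen on an aromatic carbon. Among the compounds with values here, no step between two measured compounds that differ in one place is available here, so the size of this kind of change is not yet known from these data. Compound 4 is expected to remain weak in this assay, and the step of a number no higher from compound 3 to compound 4 (the limit leaves the size open) is expected to be small, likely within the scatter. The estimate for compound 4 is 100000 nM, within 30000 nM to 300000 nM.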

Compound 4, half-maximal inhibitory concentration: > 100000 nM
Compound 4 ended at the assay's limit (the forecaster's own chance of this, stated with the estimate: 60%); the middle value sits exactly at the limit.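

In this assay, within the data shown here, compound 3 and compound 4 both sit at a limit, so no step between them can be read: the limit of > 100000 nM in this assay, at which 2 of the 4 values shown sit. The compounds shown leave open how far a methoxy in place of hydrogen on an aromatic carbon shifts inhibition.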